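Extending a sulfonamide nitrogen chain on two carbamate cores

The source may hold more compounds than are shown below. What is called first, only, known or untested is meant among the compounds shown, and "the series" means these compounds.

Compound 1 `CCCCCCCCN(C)S(=O)(=O)NC(=O)Oc1c(C(C)C)cccc1C(C)C` and compound 2 `CCCCCCCCN(CCCCCCCC)S(=O)(=O)NC(=O)Oc1c(C(C)C)cccc1C(C)C` share one core, and compound 3 `CCCCCCCCN(C)S(=O)(=O)NC(=O)Oc1c(C(C)(C)C)cc(C)cc1C(C)(C)C` and compound 4 `CCCCCCCCN(CCCCCCCC)S(=O)(=O)NC(=O)Oc1c(C(C)(C)C)cc(C)cc1C(C)(C)C` share another; the difference between the two cores is not broken down here. In an assay on liver for inhibition of sterol O-acyltransferase 1 (Rattus norvegicus), using microsomes (a lower number here means a stronger inhibitor, a higher number a weaker inhibitor), compound 1 gives 22000 nM, while compound 2 gives 58000 nM. The change between them, (heptyl in place of hydrogen on a saturated chain carbon bound to a sulfonamide nitrogen), made the number a 2.6-fold higher number from compound 1 to compound 2 (0.42 log units; beyond the scatter). Compound 3 gives 18000 nM in this assay, and its step to compound 1 lies within the usual scatter.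

Compound 4 carries the same change on the other core, (heptyl in place of hydrogen on a saturated chain carbon bound to a sulfonamide nitrogen), occurring twice among these compounds. For the measured compounds named here, because the single measured example gave a 2.6-fold higher number from compound 1 to compound 2 (0.42 log units; beyond the scatter), a step of similar size is expected on the second core; the expected step is a 2.6-fold higher number from compound 3 to compound 4 (0.42 log units; beyond the scatter). Compound 4 is therefore estimated at 47000 nM in this assay, with the likely span reaching from 20000 nM to 110000 nM. This expectation rests on one pair only, so its footing is narrow.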

Compound 4, half-maximal inhibitory concentration: 2700 nM
Beside the measured number, compound 4's estimate is 17-fold (1.24 log units) above it; measured number outside the range, below it.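

In this assay the change from methyl to octyl on the sulfonamide nitrogen did not carry over from one core to the other: the same change on two cores in this assay, a 2.6-fold higher number (0.42 log units; beyond the scatter) from compound 1 to compound 2 and a 6.7-fold lower number (0.82 log units; beyond the scatter) from compound 3 to compound 4, 18-fold (1.24 log units) apart, beyond the scatter of two such steps. On the core of compound 3 the measured step is a 6.7-fold lower number from compound 3 to compound 4 (0.82 log units; beyond the scatter), which runs opposite in direction to the step on the core of compound 1, and the step on one core therefore gave no reliable guide to the step on the other. This shows that the outcome of the change depends on the core among these four compounds, but with only one pair on each core it does not show which feature of the cores is responsible or how a further core would respond.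

The compounds shown leave open whether the same opposite directions would appear with a butyl or a dodecyl chain in place of the octyl chain. They also leave open whether a benzyl group at that nitrogen would follow the trend of either core.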